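Notes on the anilide series: 3,5-dichlorophenyl replacing 3-fluorophenyl

The source may report more compounds than this note shows. Statements on the series, on what has been measured and on what is new or still open speak of the compounds shown alone.

Measured in a functional assay on C8166 cells (Homo sapiens) for cytotoxicity, read by MTT assay; a higher number here means that more compound is tolerated, a lower number that less compound is tolerated:
Compound 1, `Cc1cc(S(N)(=O)=O)ccc1NC(=O)COc1ccc(Cl)cc1NC(=O)c1ccccc1`, gives 207000 nM.
Compound 2, `Cc1cccc(C(=O)Nc2cc(Cl)ccc2OCC(=O)Nc2ccc(S(N)(=O)=O)cc2C)c1`, gives 52900 nM.
Compound 3, `Cc1cc(S(N)(=O)=O)ccc1NC(=O)COc1ccc(Cl)cc1NC(=O)c1cccc(F)c1`, gives 243000 nM.

Compound 3 has the highest number of the three in this assay; compound 1 lies within the scatter of it, while compound 2 lies beyond it (a 4.6-fold higher number from compound 2 to compound 3 (0.66 log units; beyond the scatter)).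

Compound 4 is `Cc1cc(S(N)(=O)=O)ccc1NC(=O)COc1ccc(Cl)cc1NC(=O)c1cc(Cl)cc(Cl)c1`. Its change from compound 3: 3,5-dichlorophenyl in place of 3-fluorophenyl on a carbonyl carbon.

Bearing on it: a 1.2-fold higher number from compound 1 to compound 3 (0.07 log units; within the scatter) (no effect), but a 3.9-fold lower number from compound 1 to compound 2 (0.59 log units; beyond the scatter), a substituent added on that same ring. Among the measured compounds shown here, no dichloro analogue has been measured. A modest lowering in this assay is therefore expected for compound 4, a 3.0-fold lower number from compound 3 to compound 4 (0.48 log units; beyond the scatter), giving an estimate of 80000 nM (range 25000 nM to 250000 nM).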

Compound 4, half-maximal cytotoxic concentration: 72400 nM
For compound 4 the middle estimate is 1.1-fold (0.04 log units) above the measured one; the range from low to high includes it.
By their numbers in this assay, from the lowest: compounds 2 and 4 (each within the scatter of the next); then compounds 1 and 3 (each within the scatter of the next).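

In this assay, the 3,5-dichlorophenyl group gives a real drop against both the 3-fluorophenyl group (a 3.4-fold lower number from compound 3 to compound 4 (0.53 log units; beyond the scatter)) and the unsubstituted phenyl (a 2.9-fold lower number from compound 1 to compound 4 (0.46 log units; beyond the scatter)). Against the 3-methylphenyl group, the step (a 1.4-fold higher number from compound 2 to compound 4 (0.14 log units; within the scatter)) leaves compound 4 and compound 2 together, so of the substituted rings shown, only the 3-fluorophenyl of compound 3 stays with compound 1. Nothing available explains this.

Open, from the compounds shown here alone, is whether a single chlorine on this ring already brings the number down to that of compound 4. Also open, going by these compounds, is where an amine or a carboxylic acid on the ring would fall.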